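Bromo for Ethynyl on Two Fused Bicyclic Cores

The source may hold more compounds than are shown below. What is called first, only, known or untested is meant among the compounds shown, and "the series" means these compounds.

Three compounds have so far been measured in a functional assay on HCT-116 cells (Homo sapiens) for cytotoxicity, with a stated time of 3 days; on this read-out higher numbers stand for weaker inhibition and lower numbers for stronger inhibition:
compound 1, `C#Cc1nc2ccccc2[se]1`, 25000 nM
compound 2, `Brc1nc2ccccc2[se]1`, > 40000 nM
compound 3, `C#Cc1nc2ccccc2o1`, 11600 nM

The value of compound 2 is a limit of this assay, not a number (the limit of > 40000 nM in this assay, at which 1 of the 3 values shown sits). The change bromo in place of ethynyl on an aromatic carbon produced an at least 1.6-fold higher number from compound 1 to compound 2 (0.20 log units; that floor lies within the scatter). Compound 3 holds the lowest of the two numbers; how its core differs from that of compound 1 is not broken down here.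

Compound 4, `Brc1nc2ccccc2o1`, remains to be measured. It differs from compound 3 by bromo in place of ethynyl on an aromatic carbon, the same kind of change as before, though the five-membered ring here carries oxygen where the earlier one carried selenium. Resting on an at least 1.6-fold higher number from compound 1 to compound 2 (0.20 log units; that floor lies within the scatter), the step is expected to be a 2.6-fold higher number from compound 3 to compound 4 (0.41 log units; beyond the scatter). Compound 4 is therefore estimated at 30000 nM, expected to fall between 12000 nM and 80000 nM.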

Compound 4, half-maximal inhibitory concentration: > 40000 nM
Compound 4 ended at the assay's limit (the forecaster's own chance of this, stated with the estimate: 35%); middle value at least 1.3-fold (0.12 log units) away from the limit.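

The value of compound 4 is a limit of the assay, not a number: the limit of > 40000 nM in this assay, at which 2 of the 4 values shown sit. In this assay, bromo in place of ethynyl on an aromatic carbon gave an at least 3.4-fold higher number from compound 3 to compound 4 (0.53 log units; beyond the scatter). Both steps point towards higher numbers, and only this second one clears the scatter, so the change keeps its direction on these two cores, but whether its size carries from one core to the other is not shown: the same change on two cores in this assay, an at least 1.6-fold higher number (0.20 log units; that floor lies within the scatter) from compound 1 to compound 2 and an at least 3.4-fold higher number (0.53 log units; beyond the scatter) from compound 3 to compound 4; the limit leaves it open whether they differ.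

The compounds shown leave open how other groups would fare on this aromatic carbon, such as an amine, a nitrile or a longer chain in place of ethynyl. They also leave open whether a carboxylic acid elsewhere on either core would alter the numbers.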